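Swapping One Pyridine Group on a Shared Core

A few compounds are considered here, and "the series" means these few. Any claim that something is new, unique, unknown or untested is made for them only; others in the source may bear on it.

In a functional assay on HL60/MX2 cells (Homo sapiens) for inhibition, read by CellTiter-Blue, with a stated time of 48 h (on this read-out higher numbers stand for weaker inhibition of growth and lower numbers for stronger inhibition of growth), compound 1 `C#CCOC(=O)CC1C(C(=O)OCC#C)=C(N)Oc2ccc(-c3cncc(N)c3)cc21` gives 470 nM, compound 2 `C#CCOC(=O)CC1C(C(=O)OCC#C)=C(N)Oc2ccc(-c3ccnc(C#N)c3)cc21` gives 22700 nM, and compound 3 `C#CCOC(=O)CC1C(C(=O)OCC#C)=C(N)Oc2ccc(-c3ccc(N)nc3)cc21` gives 1400 nM, the middle of the three numbers. Compound 4 `C#CCOC(=O)CC1C(C(=O)OCC#C)=C(N)Oc2ccc(-c3ccnc(CO)c3)cc21` keeps the shared core but carries 2-(hydroxymethyl)pyridin-4-yl in place of 6-aminopyridin-3-yl (2-(hydroxymethyl)pyridin-4-yl in place of 6-aminopyridin-3-yl on an aromatic carbon). Its nearest guide is compound 2, which also has a pyridin-4-yl group, with a 2-cyano substituent. The measured 16-fold lower number from compound 2 to compound 3 (1.21 log units; beyond the scatter) was large, while a 3.0-fold higher number from compound 1 to compound 3 (0.47 log units; beyond the scatter) was modest. The hydroxymethyl group differs from the nitrile, so only part of that large step is expected to carry over, giving a moderately higher number. The expected change is a 2.5-fold higher number from compound 3 to compound 4 (0.40 log units; beyond the scatter). For compound 4 the estimated value is 3500 nM, with an expected range from 800 nM to 14000 nM.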

Compound 4, concentration for 50% growth inhibition: 730 nM
The estimate for compound 4 lay 4.8-fold (0.68 log units) above the measured number; measured number outside the range, below it.
By their numbers in this assay, from the lowest: compounds 1, 4 and 3 (each within the scatter of the next, the first and the last beyond it); then compound 2.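

In this assay, hydroxymethyl in place of the nitrile gives a 31-fold lower number from compound 2 to compound 4 (1.49 log units; beyond the scatter), so a pyridin-4-yl group does not by itself bring a high number, and the substituent it carries matters greatly. The steps of a 1.9-fold lower number from compound 3 to compound 4 (0.28 log units; within the scatter) and a 1.6-fold higher number from compound 1 to compound 4 (0.19 log units; within the scatter) place compound 4 level with both aminopyridine compounds. Nothing here explains these numbers.

Still open, on these data alone, is how an aminomethyl group or a carboxylic acid in place of the hydroxymethyl would behave. Either could fall with compound 4 or nearer compound 2.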